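Shifting methyl and trifluoromethyl on the phenoxy ring

A few compounds are considered here, and "the series" means these few. Any claim that something is new, unique, unknown or untested is made for them only; others in the source may bear on it.

Measured so far:
compound 1 `CNC(=O)c1cccc(Cn2nc(C)c(NC(=O)c3ccc(COc4ccccc4C)cc3)c2C)c1` — 2100 nM
compound 2 `CNC(=O)c1cccc(Cn2nc(C)c(NC(=O)c3ccc(COc4cccc(C)c4)cc3)c2C)c1` — 6200 nM
compound 3 `CNC(=O)c1cccc(Cn2nc(C)c(NC(=O)c3ccc(COc4ccccc4C(F)(F)F)cc3)c2C)c1` — 10000 nM

In a functional assay on MIA PaCa-2 cells (Homo sapiens) for antiproliferative activity, read by MTT assay, with a stated time of 72 h (a higher number here means that more compound is needed for the effect, a lower number that less compound is needed), compound 3 gives the highest number of the three; the gap a 1.6-fold higher number from compound 2 to compound 3 (0.21 log units; within the scatter) is within the scatter, whereas a 4.8-fold higher number from compound 1 to compound 3 (0.68 log units; beyond the scatter) is beyond it. Compound 4 `CNC(=O)c1cccc(Cn2nc(C)c(NC(=O)c3ccc(COc4ccc(C(F)(F)F)cc4C)cc3)c2C)c1` differs from compound 3 by 2-methyl-4-(trifluoromethyl)phenyl in place of 2-(trifluoromethyl)phenyl on an oxygen on a saturated carbon. For the measured compounds named here, no measured step covers this combination; the nearest are a 4.8-fold higher number from compound 1 to compound 3 (0.68 log units; beyond the scatter) and a 3.0-fold higher number from compound 1 to compound 2 (0.47 log units; beyond the scatter), both modest increases, which show that the substitution pattern on this ring matters without indicating a direction for the new pattern. Compound 4 is therefore expected to land near compound 3, with a step of a 1.7-fold lower number from compound 3 to compound 4 (0.22 log units; within the scatter) and an estimated 6000 nM, within 1500 nM to 20000 nM.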

Compound 4, half-maximal effective concentration: 620 nM
The estimate for compound 4 lay 9.7-fold (0.99 log units) above the measured number; measured number outside the range, below it.
By their numbers in this assay, from the lowest: compound 4; then compound 1; then compounds 2 and 3 (each within the scatter of the next).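

In this assay, trifluoromethyl on this ring is not a loss in itself: added to the 2-methylphenyl group it gives a 3.4-fold lower number from compound 1 to compound 4 (0.53 log units; beyond the scatter), whereas in place of the methyl it gave a 4.8-fold higher number from compound 1 to compound 3 (0.68 log units; beyond the scatter). The 2-methyl-4-(trifluoromethyl)phenyl group also stands clear of the other patterns, with a 16-fold lower number from compound 3 to compound 4 (1.21 log units; beyond the scatter) and a 10-fold lower number from compound 2 to compound 4 (1.00 log units; beyond the scatter), so among these compounds the direction depends on where trifluoromethyl sits. Nothing available explains this change.

Going by these compounds, whether a nitrile or a methoxy group could replace the trifluoromethyl remains open. So does whether 4-(trifluoromethyl)phenyl without the methyl would keep the lower number.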